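This account rests on a few compounds, and the source may have more. Where it says the series, first, only, none or still open, it means among the compounds named here.

In a functional assay (trachea) with Cavia porcellus as the target (on this read-out higher numbers stand for an effect only at larger amounts of compound and lower numbers for an effect already at smaller amounts), three compounds sharing one core have been measured. Compound 1 `C=CCCn1c(=O)c2[nH]cnc2n(CCC)c1=O` gives 200 nM, compound 2 `CCCn1c(=O)n(CCC(N)=O)c(=O)c2[nH]cnc21` gives 13100 nM, and compound 3 `CCCn1c(=O)n(CCC#N)c(=O)c2[nH]cnc21` gives 1700 nM, which puts compound 3 in the middle of the three numbers. Compound 4 `CCCn1c(=O)n(CCCOC)c(=O)c2[nH]cnc21` has not yet been measured. It differs from compound 3 by methoxymethyl in place of cyano on a saturated chain carbon, two bonds along the chain from an aromatic nitrogen.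

All three measured steps fall at this same place. Cyano in place of vinyl gave a modest 8.5-fold higher number from compound 1 to compound 3 (0.93 log units; beyond the scatter), and carbamoyl in place of vinyl gave a large 66-fold higher number from compound 1 to compound 2 (1.82 log units; beyond the scatter). Cyano in place of carbamoyl gave a modest 7.7-fold lower number from compound 2 to compound 3 (0.89 log units; beyond the scatter). The number thus moves beyond the scatter with each change of group here, but none of these steps involves methoxymethyl, so they bear on the new change only indirectly. Methoxymethyl is neither a nitrile nor an amide, and neither is the vinyl of compound 1 at 200 nM, so a modest move towards lower numbers is expected in this assay. The estimated change is a 2.8-fold lower number from compound 3 to compound 4 (0.45 log units; beyond the scatter). For compound 4 the expected value is 600 nM, with an estimated range from 180 nM to 2000 nM.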

Compound 4, half-maximal effective concentration: 2900 nM
Compound 4: the middle estimate sits 4.8-fold (0.68 log units) below what was measured, outside the stated range (above it).
By their numbers in this assay, from the lowest: compound 1; then compounds 3 and 4 (each within the scatter of the next); then compound 2.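

In this assay, methoxymethyl in place of cyano on a saturated chain carbon, two bonds along the chain from an aromatic nitrogen, gives (a 1.7-fold higher number from compound 3 to compound 4 (0.23 log units; within the scatter)), so the 2-cyanoethyl and 3-methoxypropyl chains cannot be told apart here, although the groups differ in their atoms and methoxymethyl carries one more heavy atom. The vinyl-bearing chain of compound 1 nevertheless stays clearly apart from the new chain (a 15-fold higher number from compound 1 to compound 4 (1.16 log units; beyond the scatter)), which shows that a group being neither nitrile nor amide is not enough to bring the number close to that of compound 1. The carbamoyl-bearing chain also stays apart (a 4.5-fold lower number from compound 2 to compound 4 (0.65 log units; beyond the scatter)), so among these four compounds compound 1 has the lowest number, compound 2 has the highest, and compounds 3 and 4 sit together between them.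

The compounds shown leave open how a hydroxyl, an amine, a carboxylic acid or a plain saturated alkyl chain of similar length would read at this same place, and whether a longer chain would move the number at all. No independent measurement is available that would explain the differences among these four numbers.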